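Chlorobenzyl isomer swap on the shared thioether core

This account rests on a few compounds, and the source may have more. Where it says the series, first, only, none or still open, it means among the compounds named here.

Measured so far:
- compound 1, `CC1=C(C(=O)Nc2ccc(F)cc2)C(c2ccc([N+](=O)[O-])cc2)N=C(SCc2ccccc2Cl)N1`: 21.6%
- compound 2, `CC1=C(C(=O)Nc2ccc(F)cc2)C(c2ccc([N+](=O)[O-])cc2)N=C(SCc2cccc(Cl)c2)N1`: 21.1%
- compound 3, `COc1ccc(C2N=C(SCc3ccccc3Cl)NC(C)=C2C(=O)Nc2ccc(Br)cc2)cc1`: 20.6%

All three numbers come from a functional assay on the whole organism (artery, strain albino) with Rattus norvegicus as the target, with a stated time of 360 min, at a dose of 10 mg/kg by the oral route; a higher number here means more inhibition at the dose given (going by the name of the read-out), a lower number less inhibition. Compound 1 gives 21.6% and compound 2 gives 21.1%; the two differ by 3-chlorophenyl in place of 2-chlorophenyl on a saturated chain carbon bound to a sulfur, and the step of a number 0.5 percentage points lower from compound 1 to compound 2 (within the scatter) lies within the scatter, so the pair reads as one level. Compound 3 gives 20.6% in this assay, which is also within the scatter of both compound 1 and compound 2; the difference between the core of compound 3 and that of compound 1 is not broken down here.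

Compound 4, `COc1ccc(C2N=C(SCc3cccc(Cl)c3)NC(C)=C2C(=O)Nc2ccc(Br)cc2)cc1`, is not yet measured in this assay. It differs from compound 3 by 3-chlorophenyl in place of 2-chlorophenyl on a saturated chain carbon bound to a sulfur, the same change as that from compound 1 to compound 2, made at the same place. Among the compounds with values here, the only precedent for this change, the step from compound 1 to compound 2, was flat, and every number so far sits in one narrow band, so a flat step is expected here as well: the step of a number 0.6 percentage points lower from compound 3 to compound 4 (within the scatter) is the estimate, resting on a number 0.5 percentage points lower from compound 1 to compound 2 (within the scatter). For compound 4 the expected value in this assay is 20%, with a plausible range from 10% to 30%.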

Compound 4, a percentage reported as inhibition, in the whole organism at one dose (the size of the read-out at that dose, not a potency): 39.7%
Compound 4: the middle estimate sits 19.7 percentage points below what was measured; measured number above the stated range.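

In this assay, replacing 2-chlorobenzyl with 3-chlorobenzyl on the core of compound 3 gives a number 19.1 percentage points higher from compound 3 to compound 4 (beyond the scatter), whereas the same change on the core of compound 1 gives a number 0.5 percentage points lower from compound 1 to compound 2 (within the scatter). The result of this change therefore does not carry over unchanged from one core to the other, and a step read on one of these cores is a poor guide to the step on the other: the same change on two cores in this assay, a number 0.5 percentage points lower (within the scatter) from compound 1 to compound 2 and a number 19.1 percentage points higher (beyond the scatter) from compound 3 to compound 4, 19.6 percentage points apart, beyond the scatter of two such steps

This does not show which feature of the core goes with the difference, as the two cores differ in more than one place, and two matched pairs give no rule for any further core in the series, nor any explanation of the difference.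

Still open, on these data alone, is whether the nitro or methoxy group on the aryl ring, or the fluorine or bromine on the anilide, is the part that goes with the larger step, which would take cores differing in only one of these places. Also open, as far as these compounds go, is how this assay responds when the chlorine on the benzyl ring gives way to an amine or a carboxylic acid, or when a longer chain replaces the benzyl group on the sulfur.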